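Two Amides Measured, a Third Awaiting Its Number

A few compounds are considered here, and "the series" means these few. Any claim that something is new, unique, unknown or untested is made for them only; others in the source may bear on it.

Compound 1 `CC(Cl)CC(=O)NC1=C(C#N)C(c2ccc(Cl)cc2Cl)C2=C(CCCC2=O)N1c1ccc(S(N)(=O)=O)cc1` — 50%
Compound 2 `N#CC1=C(NC(=O)c2ccccc2)N(c2ccc(S(N)(=O)=O)cc2)C2=C(C(=O)CCC2)C1c1ccc(Cl)cc1Cl` — 60%
Compound 3 `N#CC1=C(NC(=O)/C=C/c2ccccc2)N(c2ccc(S(N)(=O)=O)cc2)C2=C(C(=O)CCC2)C1c1ccc(Cl)cc1Cl` — not yet measured

In a functional assay on Ehrlich cells (Mus musculus) for cytotoxicity, read by trypan blue exclusion, with a stated time of 2 h, tested at 25 ug/mL (on this read-out higher numbers stand for a stronger effect at the one concentration tested and lower numbers for a weaker effect), compound 1 gives 50% and compound 2 gives 60%. Among the two numbers shown, compound 2 carries the one that ranks first, yet the step of a number 10 percentage points higher from compound 1 to compound 2 (within the scatter) stays within the scatter, so the pair cannot be told apart. Compound 3 differs from compound 2 in one place: 2-phenylethenyl in place of phenyl on a carbonyl carbon. For the measured compounds named here, only one measured step touches this site, the exchange of 2-chloropropyl for phenyl on the same carbonyl carbon, and it moved the number within the scatter. On that basis, for compound 3 a step in this assay of no change at the digits printed from compound 2 to compound 3 (within the scatter) is expected, that is none beyond the scatter. Compound 3 is therefore estimated at 60%, with a range from 42% to 75%.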

Compound 3, a percentage reported as activity, at one concentration (the size of the read-out at that concentration, not a potency): 30%
Compound 3: middle estimate off by 30 percentage points, on the high side; measured number outside the range, below it.
By their numbers in this assay, from the lowest: compound 3; then compounds 1 and 2 (each within the scatter of the next).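

With 2-phenylethenyl in place of phenyl on the carbonyl carbon, this assay records a number 30 percentage points lower from compound 2 to compound 3 (beyond the scatter), so this site, which showed no step beyond the scatter with the first two compounds, does respond to the group it carries. The same group in place of 2-chloropropyl gives a number 20 percentage points lower from compound 1 to compound 3 (beyond the scatter), so the fall holds against both earlier groups, although those two groups cannot be told apart from each other. No measurement at hand says what lies behind this fall.

Still open, as far as these compounds go, is whether the fall belongs to the double bond or to the added carbons, a question that a saturated 2-phenylethyl group on the same carbonyl carbon would address. Also open, from the compounds shown here alone, is how a small methyl group, or a chain ending in an amine or a carboxylic acid, would fare here.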